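The source may report more compounds than this note shows. Statements on the series, on what has been measured and on what is new or still open speak of the compounds shown alone.

Measured compounds:

- Compound 1, `COc1cc(-c2cc(/C=C/C(=O)c3ccc(N)cc3)[nH]n2)cc(OC)c1OC`: -57%
- Compound 2, `COc1ccc(-c2cc(/C=C/C(=O)c3ccc(OC)c(OC)c3)[nH]n2)cc1`: -95%
- Compound 3, `COc1cc(-c2cc(/C=C/C(=O)c3ccc(Cl)c(Cl)c3)[nH]n2)cc(OC)c1OC`: 73%

In a functional assay on SK-MEL-28 cells (Homo sapiens) for cytotoxicity, read by sulforhodamine B assay, with a stated time of 48 h, tested at 10 uM (a lower number here means a stronger effect, a higher number a weaker effect of the compound at the concentration tested), compound 1 stands second highest of the three numbers shown. Its nearest neighbour is compound 2, whose value is lower beyond the scatter; compound 3 lies far above it, and the step of a number 130 percentage points higher from compound 1 to compound 3 (beyond the scatter) is large. That step, however, concerns the ring on the carbonyl carbon, not the ring where compound 4 changes.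

Compound 4, `COc1ccc(-c2cc(/C=C/C(=O)c3ccc(N)cc3)[nH]n2)cc1OC`, differs from compound 1 in one place: hydrogen in place of methoxy on an aromatic carbon. For the measured compounds named here, no measured pair differs in exactly this way, so no step can be carried over directly. Compound 2 shows that a pyrazole-bound ring carrying fewer methoxy groups can still give a strong value, but compound 2 also differs on the carbonyl side, so it is not a guide on its own. With nothing to indicate a large shift, only a modest weakening is expected, as a number 17 percentage points higher from compound 1 to compound 4 (beyond the scatter). For compound 4 the estimate in this assay is -40%, with a range from -90% to 20%.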

Compound 4, a percentage reported as activity, at one concentration (the size of the read-out at that concentration, not a potency): -29%
For compound 4 the middle estimate is 11 percentage points below the measured one; low and high end bracket the measured number.
By their numbers in this assay, from the lowest: compound 2; then compound 1; then compound 4; then compound 3.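

In this assay, for the compounds shown here, replacing this methoxy group with hydrogen gives a number 28 percentage points higher from compound 1 to compound 4 (beyond the scatter), and this is the first reading of a change on this ring with the rest of the molecule held fixed. The methoxy group therefore makes a measurable difference to the read-out at this position, yet the number does not cross zero: compound 1 gives -57% and compound 4 gives -29%. No available evidence explains why this change shifts the number.

As far as these compounds go, it remains open whether another group at this place, such as a hydroxy group, an ethoxy group or a fluorine atom, would keep the number near that of compound 1 or raise it further. Also open, from the compounds shown here alone, is whether the same change would have a similar effect with 3,4-dichlorophenyl in place of 4-aminophenyl on the carbonyl carbon.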